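From methyl to methoxy in a cytotoxicity series

The source may hold more compounds than are shown below. What is called first, only, known or untested is meant among the compounds shown, and "the series" means these compounds.

Three compounds have been measured in a functional assay on HL-60 cells (Homo sapiens) for cytotoxicity, with a stated time of 24 h; on this read-out higher numbers stand for lower toxicity in this test and lower numbers for higher toxicity in this test:
compound 1 `O=C1/C(=C/c2ccccc2)CCC/C1=C\c1ccccc1[N+](=O)[O-]` gives 3700 nM
compound 2 `CN(C)c1ccc(/C=C2\CCC/C(=C\c3ccccc3[N+](=O)[O-])C2=O)cc1` gives > 400000 nM, which is a limit of the assay
compound 3 `Cc1ccc(/C=C2\CCC/C(=C\c3ccccc3[N+](=O)[O-])C2=O)cc1` gives 11000 nM

Compound 3 has the higher of the two actual numbers in this assay, and the remaining reading is only a limit. The next step leads to compound 4 `COc1ccc(/C=C2\CCC/C(=C\c3ccccc3[N+](=O)[O-])C2=O)cc1`, with methoxy in place of methyl on an aromatic carbon, para to a large group (methoxy in place of methyl on an aromatic carbon).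

For the measured compounds named here, three measured steps bear on this change. Placing methyl on the ring of compound 1 gave a modest change, a 3.0-fold higher number from compound 1 to compound 3 (0.47 log units; beyond the scatter). Placing dimethylamino there gave a large one, an at least 100-fold higher number from compound 1 to compound 2 (2.03 log units; beyond the scatter). The exchange between these two groups was also large, an at least 36-fold lower number from compound 2 to compound 3 (1.56 log units; beyond the scatter). Going by the values given here, both groups raised the number, and no measured compound goes against this. A modest rise is therefore expected, a 2.3-fold higher number from compound 3 to compound 4 (0.36 log units; beyond the scatter). Compound 4 is estimated at 25000 nM, with an expected range of 8000 nM to 90000 nM.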

Compound 4, half-maximal cytotoxic concentration: 26000 nM
Compound 4: the middle estimate sits 1.0-fold (0.02 log units) below what was measured; the range from low to high includes it.
By their numbers in this assay, from the lowest: compound 1; then compound 3; then compound 4. At a limit, above all of these: compound 2.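

In this assay, the aromatic carbon para to a large group now carries a third substituent with an actual number, and methoxy places compound 4 in the middle of the series: a 2.4-fold higher number from compound 3 to compound 4 (0.37 log units; beyond the scatter), and a 7.0-fold higher number from compound 1 to compound 4 (0.85 log units; beyond the scatter). The order from hydrogen through methyl and methoxy to dimethylamino has no exception among these compounds, and methoxy remains well short of dimethylamino, with an at least 15-fold lower number from compound 2 to compound 4 (1.18 log units; beyond the scatter). Compound 2 is only a limit, so this last step gives a bound and not a size: the limit of > 400000 nM in this assay, at which 1 of the 4 values shown sits.

The compounds shown leave open where a hydroxyl group or a fluorine at this place would fall in that order. They also leave open whether the same order holds with a nitrile in place of the nitro group on the other ring.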